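3,5-dihydroxyphenyl in place of 2-methoxyphenyl

The source may report more compounds than this note shows. Statements on the series, on what has been measured and on what is new or still open speak of the compounds shown alone.

In an ADME assay on MCF7 cells (Homo sapiens) for cytotoxicity, with a stated time of 72 h (a higher number here means a weaker inhibitor, a lower number a stronger inhibitor), compound 2 (`COc1ccccc1CNc1ncnc2c1ncn2C1CCCCO1`) reports > 100000 nM as a limit, not a number. Compound 1 (`Oc1cccc(CNc2ncnc3c2ncn3C2CCCCO2)c1`) reports > 100000 nM as a limit too. Compound 2 therefore stands at the limit of > 100000 nM in this assay, at which 2 of the 3 values shown sit, with no number of its own. Compound 3 (`COc1ccc(OC)c(CNc2ncnc3c2ncn3C2CCCCO2)c1`) gives 25400 nM as a real number, and its added methoxy gives an at least 3.9-fold lower number from compound 2 to compound 3 (0.59 log units; beyond the scatter) on this series.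

Compound 4 (`Oc1cc(O)cc(CNc2ncnc3c2ncn3C2CCCCO2)c1`) changes compound 2 thus (3,5-dihydroxyphenyl in place of 2-methoxyphenyl on a saturated chain carbon bound to a nitrogen on an aromatic ring) and carries no methoxy. Its hydroxy groups recall compound 1, where the swap gives a step that the two limits leave unreadable from compound 1 to compound 2 and so offers no size to carry over. No step beyond the scatter is expected, and another limit is likely. The expected move is a number no higher from compound 2 to compound 4 (the limit leaves the size open) at most. Compound 4 is estimated at 100000 nM in this assay with an expected range from 40000 nM to 250000 nM for now.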

Compound 4, half-maximal inhibitory concentration: > 100000 nM
Compound 4: no number, only a limit; the forecaster's own chance of this, stated with the estimate: 65%; the middle value lies on the limit itself.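

In this assay compound 4 gives > 100000 nM, a limit and not a number, so the steps to compound 4 from compound 1 and compound 2 cannot be read. From the compounds shown here alone, the size of any difference among compound 1, compound 2 and compound 4 stays open.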